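The source may hold more compounds than are shown below. What is called first, only, known or untested is meant among the compounds shown, and "the series" means these compounds.

Of the compounds shown here, two sharing one core have been measured in a functional assay on NALM-6 cells (Homo sapiens); on this read-out higher numbers stand for weaker inhibition and lower numbers for stronger inhibition. Compound 1, `CCCCCCCCSC[C@H](NC(C)=O)C(=O)CCl`, gives in this assay 5600 nM. Compound 2, `CCCCCCCCCSC[C@H](NC(C)=O)C(=O)CCl`, gives in this assay 7300 nM. Among these two numbers compound 2 has the higher one, yet its only neighbour is compound 1, and the step of a 1.3-fold higher number from compound 1 to compound 2 (0.12 log units; within the scatter) keeps the two within the scatter, so no order between them can be read.

Compound 3, `CCCCCCCCCCCCCSC[C@H](NC(C)=O)C(=O)CCl`, has not been measured. It differs from compound 2 by butyl in place of hydrogen on a saturated chain carbon, nine bonds along the chain from a sulfur, a longer stretch of saturated chain added at the far end, away from the sulfur. Going by the values given here, only one measured step bears on this change: the step from compound 1 to compound 2 also lengthened the chain at that end, by a single carbon, and that step of a 1.3-fold higher number from compound 1 to compound 2 (0.12 log units; within the scatter) stayed within the scatter. On that single step the expected size in this assay for a further, larger lengthening is small, and no direction beyond the scatter is expected; the step from compound 2 to compound 3 is estimated at a 1.4-fold higher number from compound 2 to compound 3 (0.14 log units; within the scatter). For compound 3 the expected value is 10000 nM, within a range from 3500 nM to 30000 nM.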

Compound 3, half-maximal inhibitory concentration: > 100000 nM
Compound 3 was reported as a limit (the forecaster's own chance of this, stated with the estimate: 15%); middle value at least 10-fold (1.00 log units) away from the limit.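

Over the single carbon that separates compound 1 from compound 2, lengthening the chain at its far end gave no readable change, but a larger extension at this end does have a clear effect in this assay: butyl in place of hydrogen on a saturated chain carbon, nine bonds along the chain from a sulfur, gives an at least 13-fold higher number from compound 2 to compound 3 (1.13 log units; beyond the scatter). Measured from the shortest chain, pentyl in place of hydrogen gives an at least 17-fold higher number from compound 1 to compound 3 (1.25 log units; beyond the scatter), so chain length at this end is not a free variable, and the extension separates compound 3 from both shorter compounds by far more than the scatter. The result for compound 3 is a limit and not a number, which means that both steps give only a minimum size: the limit of > 100000 nM in this assay, at which 1 of the 3 values shown sits.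

From the compounds shown here alone, what remains open is whether the loss of inhibition sets in gradually or abruptly for chains with lengths between those of compound 2 and compound 3. Also unresolved is how a shorter chain, or an amine or a carboxylic acid at the far end of the chain, would read out in this assay.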